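Adding One Carbon to a Long Saturated Chain

This account rests on a few compounds, and the source may have more. Where it says the series, first, only, none or still open, it means among the compounds named here.

Compound 1 `CCCCCCCNC(=O)Oc1ccc(Cl)cc1C(=O)Nc1cccc(Cl)c1` and compound 2 `CCCCCCCCNC(=O)Oc1ccc(Cl)cc1C(=O)Nc1cccc(Cl)c1` share one core and differ only by methyl in place of hydrogen on a saturated chain carbon, seven bonds along the chain from an amide-type nitrogen. In an ADME assay for metabolic stability, read by HPLC, at pH 7 (a higher number here means that the compound lasts longer, a lower number that the compound disappears faster), compound 1 gives 64 h, and compound 2 gives 64 h; the step of no change at the digits printed from compound 1 to compound 2 (within the scatter). Compound 3 `CCCCCCCCCCNC(=O)Oc1ccc(Cl)cc1C(=O)Nc1ccc(Cl)cc1` rests on a second core; how the two cores differ is not broken down here. In this assay compound 3 gives 64 h, level with compounds 1 and 2. Compound 4 `CCCCCCCCCCCNC(=O)Oc1ccc(Cl)cc1C(=O)Nc1ccc(Cl)cc1` has not yet been measured. It differs from compound 3 by methyl in place of hydrogen on a saturated chain carbon, ten or more bonds along the chain from an amide-type nitrogen. Going by the values given here, this is the same kind of change as the one between compound 1 and compound 2, though not the same: the entering methyl sits at a different place along the chain, counted from an amide-type nitrogen. Because no change at the digits printed from compound 1 to compound 2 (within the scatter), the expected step in this assay is no change at the digits printed from compound 3 to compound 4 (within the scatter). Compound 4 is therefore estimated at 64 h in this assay, with an expected range from 32 h to 128 h. Among the compounds with values here, only one measured pair supports this expectation.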

Compound 4, half-life: 64 h
Compound 4: the middle estimate sits on the measured number at the digits printed; the measured number falls inside the stated range.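

In this assay, the added methyl on the second core gives no change at the digits printed from compound 3 to compound 4 (within the scatter). Set beside the earlier step, the same change reads alike on the two cores: the same change on two cores in this assay, no change at the digits printed (within the scatter) from compound 1 to compound 2 and no change at the digits printed (within the scatter) from compound 3 to compound 4, 1.0-fold (0.00 log units) apart, within the scatter of two such steps. Going by these compounds alone, this shows that, for these two pairs, a single added carbon on a long saturated chain carried over from one core to the other without moving the half-life, but it rests on only two pairs, with the methyl entering at a different place along the chain in each, and it does not show why the half-life stays level or that the same would hold on any further core.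

The compounds shown leave open whether a chain carrying an amine or a carboxylic acid would keep the same half-life in this assay. On these data alone, whether a much shorter chain, such as propyl, would read the same on either core also remains open.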